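The compounds below may be only part of what the source reports. "The series", "measured", "known", "first", "only" and "open" are said of these compounds alone.

Working notes on the series.

Two compounds carry a measured value in a functional assay with Rattus norvegicus as the target; on this read-out lower numbers stand for stronger inhibition and higher numbers for weaker inhibition. Compound 1 `COc1cc(C(=O)/C=C(\C)c2ccncc2)cc(OC)c1OC` sits at a limit of the assay: in this assay compound 1 gives > 100000 nM, which is a limit and not a number. Among the compounds with values here, compound 2 `CC(C)(C)c1ccc(C(=O)/C=C/c2ccncc2)cc1` is the only compound with a numerical value: in this assay compound 2 gives 47000 nM. Of the values shown, one is a number and one is a limit, and the limit of > 100000 nM in this assay, at which 1 of the 2 values shown sits, marks where that limit sits. Within the data shown here, no step between two measured compounds is recorded, so nothing shows how a change at the aromatic carbon moves the read-out.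

Compound 3 `CSc1ccc(C(=O)/C=C/c2ccncc2)cc1` differs from compound 2 in one place: methylsulfanyl in place of tert-butyl on an aromatic carbon. Among the measured compounds shown here, with no measured step to lean on, the expected step from compound 2 to compound 3 is a 1.0-fold lower number from compound 2 to compound 3 (0.02 log units; within the scatter), that is, none beyond the scatter. For compound 3 in this assay the estimate is 45000 nM, in the range 15000 nM to 130000 nM.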

Compound 3, half-maximal inhibitory concentration: 33000 nM
Beside the measured number, compound 3's estimate is 1.4-fold (0.13 log units) above it, within the range that was stated.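

Within the data shown here, this is the first measured step: in this assay, methylsulfanyl in place of tert-butyl on an aromatic carbon gives a 1.4-fold lower number from compound 2 to compound 3 (0.15 log units; within the scatter). At this position, on a six-membered aromatic ring of carbon only and para to a large group, a group of 4 heavy atoms with no hydrogen-bond acceptor gives way to one of 2 heavy atoms with 1 hydrogen-bond acceptor, and the read-out shows no change beyond the scatter. Nothing measured here bears on a cause for this step.

Going by these compounds, it remains open whether an amine, a carboxylic acid or a longer chain on this aromatic carbon would move the read-out beyond the scatter. A single step also cannot tell whether the same exchange would read the same way on another core.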